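Hydroxylation of compound 3: expected cytotoxicity of compound 4

The source may report more compounds than this note shows. Statements on the series, on what has been measured and on what is new or still open speak of the compounds shown alone.

Compound 1 `C[C@]1(O)C[C@@H](OC(=O)/C=C/c2ccccc2)[C@@H]2C=CO[C@@H](O[C@@H]3O[C@H](CO)[C@@H](O)[C@H](O)[C@H]3O)[C@@H]21`, compound 2 `COc1cc([C@@H]2Oc3c(O)cc(/C=C/C(=O)O[C@@H]4C[C@](C)(O)[C@H]5[C@H](O[C@@H]6O[C@H](CO)[C@@H](O)[C@H](O)[C@H]6O)OC=C[C@H]54)cc3[C@H]2CO)ccc1O` and compound 3 `CC(/C=C/[C@@]1(O)C(C)(C)CCC[C@@]1(C)O)=C\C(=O)O[C@@H]1C[C@](C)(O)[C@H]2[C@H](O[C@@H]3O[C@H](CO)[C@@H](O)[C@H](O)[C@H]3O)OC=C[C@H]21` share a common core and differ only in the ester part. In a functional assay on BGC-823 cells (Homo sapiens) for cytotoxicity, read by MTT assay, with a stated time of 4 days (a lower number here means a stronger inhibitor, a higher number a weaker inhibitor), compound 1 gives only the limit > 10000 nM. Compound 2 likewise returns only the limit > 10000 nM in this assay. Compound 3 stands at that same limit, > 10000 nM, with no number behind it; (the limit of > 10000 nM in this assay, at which 3 of the 3 values shown sit). Compound 4 `CC(/C=C/[C@@]1(O)C(C)(C)CC[C@@H](O)[C@@]1(C)O)=C\C(=O)O[C@@H]1C[C@](C)(O)[C@H]2[C@H](O[C@@H]3O[C@H](CO)[C@@H](O)[C@H](O)[C@H]3O)OC=C[C@H]21` is not yet measured; from compound 3 it differs by hydroxy in place of hydrogen on a saturated ring carbon. With every shown value sitting at the limit, no measured step exists to size this change against, and nothing among the three compounds points to a gain. The expected step that the limit leaves unreadable from compound 3 to compound 4 is none beyond the scatter. Compound 4 is therefore expected to give 15000 nM, within 5000 nM to 50000 nM, most likely again only as a limit.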

Compound 4, half-maximal inhibitory concentration: > 10000 nM
Compound 4: only a limit was reported; the forecaster's own chance of this, stated with the estimate: 85%; the middle value is on the limit's open side.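

In this assay no step can be read from compound 3 to compound 4, since both report only a limit: the limit of > 10000 nM in this assay, at which 4 of the 4 values shown sit.

The compounds shown leave open whether any ester part on the shared core gives a readable value in this assay.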